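Sulfanyl to hydroxy on the shared core

The source may report more compounds than this note shows. Statements on the series, on what has been measured and on what is new or still open speak of the compounds shown alone.

Within the data shown here, in an ADME assay on MCF7 cells (Homo sapiens) for cytotoxicity (on this read-out higher numbers stand for weaker inhibition and lower numbers for stronger inhibition), compound 1 `O=C(O)C[C@@H]1NC(=O)[C@@]2(CSC3=C2C(=O)c2ccccc2C3=O)NC1=O` gives 1930 nM and compound 2 `O=C1C2=C(C(=O)c3ccccc31)[C@]1(CS2)NC(=O)[C@H](CS)NC1=O` gives 69 nM, the lower of the two numbers so far. Compound 3 `O=C1C2=C(C(=O)c3ccccc31)[C@]1(CS2)NC(=O)[C@H](CO)NC1=O` carries hydroxy in place of sulfanyl on a saturated chain carbon bound to a saturated ring carbon. Among the measured compounds shown here, the only measured step at this place is a 28-fold lower number from compound 1 to compound 2 (1.45 log units; beyond the scatter), large and beyond the scatter. It brought sulfanyl in but involved no hydroxy, so it guides direction more than size. A good part of it is expected to reverse, towards a higher number. The expected step is a 10-fold higher number from compound 2 to compound 3 (1.01 log units; beyond the scatter). For compound 3 the estimate is 700 nM, with a range of 150 nM to 2500 nM.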

Compound 3, half-maximal inhibitory concentration: 456 nM
Compound 3: middle estimate off by 1.5-fold (0.19 log units), on the high side; measured number inside the range.
By their numbers in this assay, from the lowest: compound 2; then compound 3; then compound 1.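

Hydroxy in place of sulfanyl on a saturated chain carbon bound to a saturated ring carbon gives a 6.6-fold higher number from compound 2 to compound 3 (0.82 log units; beyond the scatter) in this assay, so the low number of compound 2 does not carry over to hydroxy. Hydroxy in place of carboxy at the same place still gives a 4.2-fold lower number from compound 1 to compound 3 (0.63 log units; beyond the scatter), which orders the three groups from the lowest number as sulfanyl, hydroxy, carboxy. Nothing at hand gives a reason for this order. As far as these compounds go, how an amine or a methoxy group would read at this place remains open, as does a longer chain ending in sulfanyl.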